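From 1-carboxyethyl to 1,3-dicarboxypropyl on the amide-type nitrogen

A few compounds are considered here, and "the series" means these few. Any claim that something is new, unique, unknown or untested is made for them only; others in the source may bear on it.

Measured so far in a functional assay on BXPC-3 cells (Homo sapiens) for antiproliferative activity, read by MTT assay, with a stated time of 24 h; a higher number here means a weaker inhibitor, a lower number a stronger inhibitor (two compounds)
- compound 1 `CCn1c(C(=O)N[C@H](C)CO)ccc1C(CC)(CC)c1ccc(OCS(=O)(=O)c2ccccc2)c(C)c1` gives 10000 nM as its value
- compound 2 `CCn1c(C(=O)N[C@H](C)C(=O)O)ccc1C(CC)(CC)c1ccc(OCS(=O)(=O)c2ccccc2)c(C)c1` gives 20100 nM as its value

Among the measured compounds shown here, compound 2 lies within the scatter of compound 1, the only other measured compound, so the pair sets no order. The unmeasured compound 3 `CCn1c(C(=O)N[C@@H](CCC(=O)O)C(=O)O)ccc1C(CC)(CC)c1ccc(OCS(=O)(=O)c2ccccc2)c(C)c1` carries 1,3-dicarboxypropyl in place of 1-carboxyethyl on an amide-type nitrogen and keeps the shared core. For the measured compounds named here, one measured step bears on this change: carboxy in place of hydroxymethyl on the same side chain, a 2.0-fold higher number from compound 1 to compound 2 (0.30 log units; within the scatter), a step that stays within the scatter. What a further carboxy does is not shown by the data, and a single step is a thin guide. On the evidence of that step, no change beyond the scatter is expected in this assay, and the range is kept wide. The estimated value for compound 3 is 25000 nM, with an expected range from 10000 nM to 60000 nM in this estimate. The expected step is a 1.2-fold higher number from compound 2 to compound 3 (0.09 log units; within the scatter) by this estimate.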

Compound 3, half-maximal inhibitory concentration: > 50000 nM
Compound 3: only a limit was reported (the forecaster's own chance of this, stated with the estimate: 20%); middle value at least 2.0-fold (0.30 log units) away from the limit.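

In this assay compound 3 gives > 50000 nM, which is a limit of the assay and not a number. The side chain on the amide-type nitrogen now separates compounds beyond the scatter, which the earlier pair did not show: 1,3-dicarboxypropyl in place of 1-carboxyethyl gives an at least 2.4-fold higher number from compound 2 to compound 3 (0.39 log units; beyond the scatter), and 1,3-dicarboxypropyl in place of 1-(hydroxymethyl)ethyl gives an at least 5.0-fold higher number from compound 1 to compound 3 (0.69 log units; beyond the scatter). Both steps rest on that limit, so they fix only a minimum size for the change and leave its full extent unknown: the limit of > 50000 nM in this assay, at which 1 of the 3 values shown sits.

The change from 1-carboxyethyl to 1,3-dicarboxypropyl lengthens the chain and adds a second carboxylic acid in one move, and the compounds shown cannot separate these two contributions. Open questions are whether a longer chain without the second carboxylic acid, such as a plain propyl-type chain ending in a single hydroxymethyl, keeps a value nearer compound 1, and whether a terminal primary amide or amine in place of the second carboxylic acid gives the same step.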